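The compounds below may be only part of what the source reports. "The series", "measured", "known", "first", "only" and "open" are said of these compounds alone.

Measured so far:
Compound 1, `Nc1nc2c(c(-c3cccs3)cn2[C@@H]2O[C@H](CO)[C@@H](O)[C@H]2O)c(=O)[nH]1`: 19800 nM
Compound 3, `Nc1nc2c(c(-c3ccoc3)cn2[C@@H]2O[C@H](CO)[C@@H](O)[C@H]2O)c(=O)[nH]1`: 17600 nM
Compound 2, `CSc1ncnc2c1c(-c1ccoc1)cn2[C@@H]1O[C@H](CO)[C@@H](O)[C@H]1O`: 100 nM

In a functional assay on HCT-116 cells (Homo sapiens), read by MTT assay, with a stated time of 72 h (a lower number here means a stronger inhibitor, a higher number a weaker inhibitor), compound 2 gives the lowest of the three numbers, and compound 3 and compound 1 each sit far higher, at a distance beyond the scatter. The difference between the core of compound 2 and the core of compound 3 is not broken down here. Between compound 3 and compound 1 one change is made, (thiophen-2-yl in place of furan-3-yl on an aromatic carbon), and it moved the number by a 1.1-fold higher number from compound 3 to compound 1 (0.05 log units; within the scatter), a step within the scatter.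

Compound 4, `CSc1ncnc2c1c(-c1cccs1)cn2[C@@H]1O[C@H](CO)[C@@H](O)[C@H]1O`, has not yet been measured in this assay. It differs from compound 2 by thiophen-2-yl in place of furan-3-yl on an aromatic carbon, the same change made at the same place, now on the core of compound 2. Because that change gave only a 1.1-fold higher number from compound 3 to compound 1 (0.05 log units; within the scatter) on the core of compound 3, compound 4 is expected to differ from its parent by about a 1.1-fold higher number from compound 2 to compound 4 (0.04 log units; within the scatter). The estimate for compound 4 in this assay is 110 nM, with a likely range from 45 nM to 280 nM.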

Compound 4, half-maximal inhibitory concentration: > 20000 nM
Compound 4 was reported as a limit; the forecaster's own chance of this, stated with the estimate: 2%; middle value at least 180-fold (2.25 log units) away from the limit.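

In this assay compound 4 gives > 20000 nM, which is a limit of the assay and not a number. On the core of compound 2 the change of furan-3-yl to thiophen-2-yl gives an at least 200-fold higher number from compound 2 to compound 4 (2.30 log units; beyond the scatter), so the near-silent step seen on the core of compound 3 did not carry over, and the two steps differ: the same change on two cores in this assay, a 1.1-fold higher number (0.05 log units; within the scatter) from compound 3 to compound 1 and an at least 200-fold higher number (2.30 log units; beyond the scatter) from compound 2 to compound 4, at least 170-fold (2.24 log units) apart, beyond the scatter of two such steps. This shows that, for these four compounds, the effect of this change depends on the core, but it does not show why, and the full size of the step remains unknown, as compound 4 stands at the limit: the limit of > 20000 nM in this assay, at which 1 of the 4 values shown sits.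

The compounds shown leave open whether a thiophen-3-yl or a furan-2-yl group at the same place would follow compound 2 or compound 4 on the core of compound 2. They also leave open how a phenyl group there would behave on either core.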